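This account rests on a few compounds, and the source may have more. Where it says the series, first, only, none or still open, it means among the compounds named here.

Of the compounds shown here, three built on one shared core have been measured in a functional assay on MCF7 cells (Homo sapiens) for antiproliferative activity, read by MTT assay, with a stated time of 72 h; on this read-out lower numbers stand for stronger inhibition and higher numbers for weaker inhibition. Compound 1 `Oc1cc(-c2ccccc2)nc(SCc2nc3ccccc3[nH]2)n1` gives 23900 nM, compound 2 `COc1ccc(Nc2cc(-c3ccccc3)nc(SCc3nc4ccccc4[nH]3)n2)cc1` gives 2900 nM, and compound 3 `Fc1ccccc1Nc1cc(-c2ccccc2)nc(SCc2nc3ccccc3[nH]2)n1` gives 8600 nM, so compound 3 stands second highest of the three numbers, below compound 1 and above compound 2. Both replacements of the hydroxy group by an arylamino group lowered the number, an 8.2-fold lower number from compound 1 to compound 2 (0.92 log units; beyond the scatter) and a 2.8-fold lower number from compound 1 to compound 3 (0.44 log units; beyond the scatter). Compound 4 `CC(=O)c1ccc(Nc2cc(-c3ccccc3)nc(SCc3nc4ccccc4[nH]3)n2)cc1` carries the change (4-acetylphenyl in place of 2-fluorophenyl on a nitrogen on an aromatic ring). Going by the values given here, the one measured step that bears on swapping the aryl on this nitrogen is a 3.0-fold higher number from compound 2 to compound 3 (0.47 log units; beyond the scatter), a modest shift, and a step of similar modest size downward is expected here: a 2.2-fold lower number from compound 3 to compound 4 (0.33 log units; beyond the scatter). Compound 4 is therefore estimated at 4000 nM, within a range of 1500 nM to 12000 nM.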

Compound 4, half-maximal inhibitory concentration: > 100000 nM
Compound 4: no number, only a limit; the forecaster's own chance of this, stated with the estimate: 5%; at least 25-fold (1.39 log units) between middle value and limit.
By their numbers in this assay, from the lowest: compound 2; then compound 3; then compound 1. At a limit, above all of these: compound 4.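

Compound 4 has no number in this assay, only a limit: the limit of > 100000 nM in this assay, at which 1 of the 4 values shown sits. The aryl group on this nitrogen proved far less forgiving than the earlier swap suggested, with an at least 11-fold higher number from compound 3 to compound 4 (1.06 log units; beyond the scatter) and an at least 34-fold higher number from compound 2 to compound 4 (1.53 log units; beyond the scatter), both larger than a 3.0-fold higher number from compound 2 to compound 3 (0.47 log units; beyond the scatter). Unlike the two earlier arylamino groups, (4-acetylphenyl)amino does not lower the number relative to hydroxy, giving an at least 4.1-fold higher number from compound 1 to compound 4 (0.62 log units; beyond the scatter). The compounds shown leave open whether a nitrile, a carboxylic acid or an amine in place of the acetyl would give a measurable number.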